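The source may hold more compounds than are shown below. What is called first, only, known or untested is meant among the compounds shown, and "the series" means these compounds.

Compound 1 `Oc1ccccc1-c1cc(-c2ccsc2)cc(-c2ccccc2O)n1`, compound 2 `Oc1cccc(-c2cc(-c3ccsc3)cc(-c3ccccc3O)n2)c1` and compound 3 `Oc1ccccc1-c1cc(-c2ccccn2)cc(-c2ccccc2O)n1` share a core and were tested in a functional assay on HeLa cells (Homo sapiens) for cytotoxicity, read by CCK-8 assay; a lower number here means a stronger inhibitor, a higher number a weaker inhibitor. In this assay compound 1 gives only a limit, > 50000 nM. Compound 2 likewise gives only a limit, > 50000 nM. Compound 3 also gives only a limit, > 50000 nM. The step that the two limits leave unreadable from compound 1 to compound 2 therefore cannot be sized, and neither can a step that the two limits leave unreadable from compound 1 to compound 3; every measured value sits at the limit of > 50000 nM in this assay, at which 3 of the 3 values shown sit. Compound 4 `Oc1cccc(-c2cc(-c3ccccn3)cc(-c3ccccc3O)n2)c1` has not yet been measured. It differs from compound 3 by 3-hydroxyphenyl in place of 2-hydroxyphenyl on an aromatic carbon, the same kind of change as 3-hydroxyphenyl in place of 2-hydroxyphenyl on an aromatic carbon between compound 1 and compound 2, though there the place is meta to a thiophen-3-yl group and here it is meta to a pyridin-2-yl group. The two cores differ by pyridin-2-yl in place of thiophen-3-yl on an aromatic carbon. Because all three measured values sit at the limit of > 50000 nM in this assay, at which 3 of the 3 values shown sit, only a small step is expected, a step that the limit leaves unreadable from compound 3 to compound 4. Compound 4 is estimated at 80000 nM, between 30000 nM and 300000 nM, most probably again reported as a limit.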

Compound 4, half-maximal inhibitory concentration: 2020 nM
The estimate for compound 4 lay 40-fold (1.60 log units) above the measured number; the measured number lies below the stated range.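

In this assay, 3-hydroxyphenyl in place of 2-hydroxyphenyl on the core carrying pyridin-2-yl gives an at least 24-fold lower number from compound 3 to compound 4 (1.39 log units; beyond the scatter), and pyridin-2-yl in place of thiophen-3-yl alongside 3-hydroxyphenyl gives an at least 24-fold lower number from compound 2 to compound 4 (1.39 log units; beyond the scatter). Compound 4 alone among the four has a true number, so each of these steps gives a minimum size, not an exact one. Whether the hydroxyl shift carries from one core to the other cannot be said, because the same change from compound 1 to compound 2, like the other earlier steps, cannot be read: the limit of > 50000 nM in this assay, at which 3 of the 4 values shown sit.

The compounds shown leave open whether 3-hydroxyphenyl and pyridin-2-yl must occur together for this result. They also leave open what an amine or a carboxylic acid would do in place of the hydroxyl.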